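Shortening the ether side chain on the shared core

The compounds below may be only part of what the source reports. "The series", "measured", "known", "first", "only" and "open" are said of these compounds alone.

Compound 1 `CCCOCCn1c(N2CCN(C)CC2)nc2ccccc21` and compound 2 `CCCCOCCn1c(N2CCN(C)CC2)nc2ccccc21` share one core and differ only in the ether side chain. In a functional assay on ileum for inhibition of histamine H1 receptor (Cavia porcellus) (on this read-out lower numbers stand for stronger inhibition and higher numbers for weaker inhibition), compound 1 gives 20 nM, and compound 2 gives 38 nM. Going by the values given here, the single measured step, a 1.9-fold higher number from compound 1 to compound 2 (0.28 log units; within the scatter), is within the scatter, so compound 2 stands beside compound 1 with no separation established between the two.

Compound 3 `COCCCn1c(N2CCN(C)CC2)nc2ccccc21` has not yet been measured. It differs from compound 2 by methoxymethyl in place of butoxy on a saturated chain carbon, two bonds along the chain from an aromatic nitrogen. Among the compounds with values here, the one measured step bears on this change only loosely: a methyl in place of hydrogen on the chain, three bonds along from the oxygen, left the number within the scatter. Within the data shown here, the change to compound 3 shortens the same chain, which no measured step covers. Compound 3 is therefore expected to stay near compound 2, with a step of about a 1.5-fold lower number from compound 2 to compound 3 (0.18 log units; within the scatter) and a value estimated at 25 nM, in the range 8 nM to 80 nM.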

Compound 3, half-maximal inhibitory concentration: 860 nM
Compound 3: the middle estimate sits 34-fold (1.54 log units) below what was measured; measured number above the stated range.
By their numbers in this assay, from the lowest: compounds 1 and 2 (each within the scatter of the next); then compound 3.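

At this place, on a saturated chain carbon, two bonds along the chain from an aromatic nitrogen, the side chain is not indifferent to change: in this assay, methoxymethyl in place of butoxy gives a 23-fold higher number from compound 2 to compound 3 (1.35 log units; beyond the scatter), and methoxymethyl in place of propoxy gives a 43-fold higher number from compound 1 to compound 3 (1.63 log units; beyond the scatter). Going by these compounds alone, both steps lie beyond the scatter, whereas the one earlier step stayed within it, so the read-out does respond to this chain, and the 3-methoxypropyl chain of compound 3 stands clearly apart. Nothing available on these compounds accounts for the size of these steps.

The change alters both the group on the ether oxygen and the place of that oxygen in the chain, and the compounds shown do not separate the two. On these data alone, how a 2-ethoxyethyl chain, or an amine in place of the ether oxygen, would read remains open.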